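Working notes: from compound 2 to compound 4

The source may hold more compounds than are shown below. What is called first, only, known or untested is meant among the compounds shown, and "the series" means these compounds.

Values in a functional assay on HCT-116 cells (Homo sapiens) for antiproliferative activity, read by MTT assay, with a stated time of 72 h; a lower number here means a stronger inhibitor, a higher number a weaker inhibitor:
- compound 1 `O=C(CCc1cccc2c1B(O)OC2)Nc1cccc(-c2ccccc2)c1`: 890 nM
- compound 2 `O=C(CCc1cccc2c1B(O)OC2)Nc1cccc(-c2ccc(F)cc2)c1`: 550 nM
- compound 3 `O=C(CCc1cccc2c1B(O)OC2)Nc1cccc(-c2ccc(OC(F)(F)F)cc2)c1`: 730 nM
- compound 4 `CSc1cccc(-c2cccc(NC(=O)CCc3cccc4c3B(O)OC4)c2)c1`: not yet measured

Compound 2 stands at 550 nM, and its number does not separate from those of the other two measured compounds: the steps are a 1.6-fold lower number from compound 1 to compound 2 (0.21 log units; within the scatter) and a 1.3-fold higher number from compound 2 to compound 3 (0.12 log units; within the scatter). The change now in view is 3-(methylsulfanyl)phenyl in place of 4-fluorophenyl on an aromatic carbon. Among the measured compounds shown here, no measured compound carries this group, so the evidence is indirect. The closest guide is the set of substituent changes already measured, which adds a 1.2-fold lower number from compound 1 to compound 3 (0.09 log units; within the scatter) to the two steps above. All three stay within the scatter, so no step beyond the scatter is expected in this assay, and no firm direction can be drawn from them. The estimated step is a 1.3-fold higher number from compound 2 to compound 4 (0.10 log units; within the scatter), which is expected to stay inside the scatter. For compound 4 the estimated value is 700 nM, with an expected range of 300 nM to 1600 nM.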

Compound 4, half-maximal inhibitory concentration: 110 nM
Estimate against measurement, compound 4: 6.4-fold (0.80 log units) above; the measured number lies below the stated range.
By their numbers in this assay, from the lowest: compound 4; then compounds 2, 3 and 1 (each within the scatter of the next).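

The outer aryl group can move the number in this assay after all: an 8.1-fold lower number from compound 1 to compound 4 (0.91 log units; beyond the scatter) is a step beyond the scatter, while a 1.6-fold lower number from compound 1 to compound 2 (0.21 log units; within the scatter) and a 1.2-fold lower number from compound 1 to compound 3 (0.09 log units; within the scatter) stayed within it. The change from 4-fluorophenyl to 3-(methylsulfanyl)phenyl also separates, with a 5.0-fold lower number from compound 2 to compound 4 (0.70 log units; beyond the scatter) likewise beyond the scatter, so this position tolerates more than the fluoro and trifluoromethoxy compounds could show. Nothing measured here accounts for this gain.

Compound 2 and compound 4 differ in both the substituent and its place on the outer ring, so the compounds shown cannot tell which of the two carries the step. From the compounds shown here alone, whether a methoxy group or a methylsulfonyl group in place of methylsulfanyl would give a step of similar size also remains open.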